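Working notes: nitro step from compound 1

The source may hold more compounds than are shown below. What is called first, only, known or untested is meant among the compounds shown, and "the series" means these compounds.

compound 1 `O=C(CCCCC(S)CCS)Nc1ccccc1`: 11.6%
compound 2 `O=C(CCCCC(S)CCS)Nc1ccccc1Cl`: "not active" (no number reported)

Going by the values given here, in a functional assay on KB cells (Homo sapiens) for inhibition, read by MTT assay, with a stated time of 24 h, tested at 1 ug/mL (on this read-out higher numbers stand for more inhibition of growth at the one concentration tested and lower numbers for less inhibition of growth), compound 1 gives 11.6%, the only number so far, so it has nothing numeric to stand against. Compound 2 is the one other entry and carries no number. Compound 3 `O=C(CCCCC(S)CCS)Nc1ccc([N+](=O)[O-])cc1` keeps the core of compound 1 and has nitro in place of hydrogen on an aromatic carbon, para to a large group: nitro in place of hydrogen on an aromatic carbon. Among the compounds with values here, no measured step is available to scale this change, so no move beyond the scatter is expected in this assay, in either direction. The estimated change is a number 0.4 percentage points higher from compound 1 to compound 3 (within the scatter). Compound 3 is estimated at 12%, with an expected range of 0% to 30%.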

Compound 3, percent growth inhibition at one concentration: 0.93%
Beside the measured number, compound 3's estimate is 11.1 percentage points above it; the range from low to high includes it.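

In this assay, going by these compounds alone, nitro in place of hydrogen on an aromatic carbon, para to a large group, gives a number 10.7 percentage points lower from compound 1 to compound 3 (beyond the scatter) and so provides the first step that can be sized. This position therefore responds to substitution, and here the change goes with less growth inhibition at the one concentration tested. Nothing at hand explains the step. Going by these compounds, whether an amine or a carboxylic acid at this same place would also lower the number remains open, as does whether the loss is particular to nitro.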